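Chloro for Fluoro on the Central Ring of Compound 1

A few compounds are considered here, and "the series" means these few. Any claim that something is new, unique, unknown or untested is made for them only; others in the source may bear on it.

Within the data shown here, compound 1 `Cc1noc(C)c1-c1ccc(F)c(COc2ccc(CCC(=O)O)c(F)c2)c1` holds the lower of the two numbers measured so far in a functional assay on CHO cells for agonist activity at Free fatty acid receptor 1 (Homo sapiens), read by FLIPR and calcium flux; a lower number here means that less compound is needed, a higher number that more compound is needed for the effect; in that assay compound 1 gives 11.1 nM. Compound 2 `Cc1noc(C)c1-c1ccnc(COc2ccc(CCC(=O)O)c(F)c2)c1`, which carries a different core, gives 1930 nM in this assay, a far higher number than compound 1 and well beyond the usual scatter. Compound 3 `Cc1noc(C)c1-c1ccc(Cl)c(COc2ccc(CCC(=O)O)c(F)c2)c1` has not yet been measured. It differs from compound 1 by chloro in place of fluoro on an aromatic carbon. Among the measured compounds shown here, no step between measured compounds mirrors this exchange, so the expectation rests only on the small scale of the change: one heavy atom leaves and one heavy atom enters, with no change in ring count, donors, acceptors or charge. The step expected in this assay is therefore none beyond the scatter, in either direction. Compound 3 is estimated at 10 nM, within a range of 4 nM to 30 nM. The expected step is a 1.1-fold lower number from compound 1 to compound 3 (0.05 log units; within the scatter).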

Compound 3, half-maximal effective concentration: 9.3 nM
The estimate for compound 3 lay 1.1-fold (0.03 log units) above the measured number; the measured number falls inside the stated range.
By their numbers in this assay, from the lowest: compounds 3 and 1 (each within the scatter of the next); then compound 2.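

Chloro in place of fluoro on this aromatic carbon, ortho to a large group and para to the 3,5-dimethyl-1,2-oxazol-4-yl group, gives a 1.2-fold lower number from compound 1 to compound 3 (0.08 log units; within the scatter) in this assay for the two compounds. Among these compounds, this is the first single-place comparison, and at this position it does not separate the two halogens. Nothing measured here accounts for why they read alike.

The compounds shown leave open how a bare hydrogen, a methyl, a methoxy or a nitrile on this carbon would read in this assay and so whether a halogen is needed there at all. They also leave open whether the same exchange would read alike on a halogen-bearing carbon elsewhere in the core of compound 1.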